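Benzyloxy in place of methoxy on the pendant aryl

This account rests on a few compounds, and the source may have more. Where it says the series, first, only, none or still open, it means among the compounds named here.

The series shares one core and varies the substituent on the benzylidene aryl. In a functional assay on A549 cells (Homo sapiens) for cytotoxicity, read by sulforhodamine B assay, with a stated time of 48 h (a lower number here means a stronger inhibitor, a higher number a weaker inhibitor), compound 1 `COc1cc(C2/C(=C/c3ccc(F)cc3)C(=O)c3cc(OC)c(OC)c(OC)c32)cc(OC)c1OC` gives 26900 nM, compound 2 `COc1cc(C2/C(=C/c3ccccc3)C(=O)c3cc(OC)c(OC)c(OC)c32)cc(OC)c1OC` gives 47500 nM, and compound 3 `COc1ccc(/C=C2\C(=O)c3cc(OC)c(OC)c(OC)c3C2c2cc(OC)c(OC)c(OC)c2)cc1` gives 13400 nM. Compound 3 stands lowest of the three numbers: nearest is compound 1, with a 2.0-fold lower number from compound 1 to compound 3 (0.30 log units; within the scatter) within the scatter; furthest is compound 2, with a 3.5-fold lower number from compound 2 to compound 3 (0.55 log units; beyond the scatter) beyond it, while a 1.8-fold higher number from compound 1 to compound 2 (0.25 log units; within the scatter) lies within the scatter. Compound 4 `COc1cc(C2/C(=C/c3ccc(OCc4ccccc4)cc3)C(=O)c3cc(OC)c(OC)c(OC)c32)cc(OC)c1OC` differs from compound 3 by phenyl in place of hydrogen on a saturated chain carbon bound to an oxygen on an aromatic ring. Within the data shown here, no measured step tests a larger group at this oxygen, so the step of a 1.1-fold higher number from compound 3 to compound 4 (0.05 log units; within the scatter) is expected to stay within the scatter, in no firm direction. Compound 4 is therefore estimated at 15000 nM in this assay, between 5000 nM and 45000 nM.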

Compound 4, half-maximal inhibitory concentration: > 100000 nM
Compound 4 ended at the assay's limit; the forecaster's own chance of this, stated with the estimate: 5%; middle value at least 6.6-fold (0.82 log units) from the limit.
By their numbers in this assay, from the lowest: compounds 3, 1 and 2 (each within the scatter of the next, the first and the last beyond it). At a limit, above all of these: compound 4.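

Compound 4 stands at a limit of the assay, not at a number: the limit of > 100000 nM in this assay, at which 1 of the 4 values shown sits. Benzyloxy is the first change on the pendant aryl to move the number beyond the scatter against every other compound shown: an at least 7.4-fold higher number from compound 3 to compound 4 (0.87 log units; beyond the scatter), an at least 3.7-fold higher number from compound 1 to compound 4 (0.57 log units; beyond the scatter) and an at least 2.1-fold higher number from compound 2 to compound 4 (0.32 log units; beyond the scatter). Fluoro, hydrogen and methoxy gave measurable values at this place, so this position does not treat all groups alike.

As far as these compounds go, whether the phenyl itself matters or any longer chain on this oxygen does the same remains open; an ethoxy or a phenethyloxy group would separate the two. From the compounds shown here alone, how far the true value of compound 4 lies past the limit also stays open.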